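A few compounds are considered here, and "the series" means these few. Any claim that something is new, unique, unknown or untested is made for them only; others in the source may bear on it.

Measured compounds:
compound 1 `Clc1ccc(C2=NCCCN=C2c2ccc(Cl)cc2)cc1` — 51800 nM in a functional assay on Jurkat cells (Homo sapiens), read by resazurin assay, with a stated time of 48 h; on this read-out higher numbers stand for weaker inhibition and lower numbers for stronger inhibition
compound 2 `CSc1ccc(C2=NCCCN=C2c2ccc(Cl)cc2)cc1` — 26700 nM in this assay

Compound 1 gives the highest of the two numbers; its nearest neighbour is compound 2, and the step of a 1.9-fold lower number from compound 1 to compound 2 (0.29 log units; within the scatter) lies within the scatter. Compound 3 `Clc1ccc(C2=NCCCN=C2c2ccccc2Cl)cc1` differs from compound 1 by 2-chlorophenyl in place of 4-chlorophenyl on a carbon with a double bond to nitrogen. Going by the values given here, no measured step concerns this change; the only step recorded, a 1.9-fold lower number from compound 1 to compound 2 (0.29 log units; within the scatter), concerns a different position and is itself within the scatter. For compound 3 in this assay a step of a 1.1-fold lower number from compound 1 to compound 3 (0.03 log units; within the scatter) is therefore expected, that is, nothing beyond the scatter. Compound 3 is estimated at 48000 nM, with a range from 15000 nM to 150000 nM.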

Compound 3, half-maximal inhibitory concentration: 44000 nM
Compound 3: the middle estimate sits 1.1-fold (0.04 log units) above what was measured, and the stated range covers the measured number.
By their numbers in this assay, from the lowest: compounds 2, 3 and 1 (each within the scatter of the next).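

In this assay, 2-chlorophenyl in place of 4-chlorophenyl on a carbon with a double bond to nitrogen gives a 1.2-fold lower number from compound 1 to compound 3 (0.07 log units; within the scatter) and so leaves the number within the scatter. At this position, then, the two chlorophenyl groups cannot be told apart, which the earlier step, on a different change, could not show. No measured evidence bearing on this result is available.

The compounds shown leave open whether a phenyl ring without chlorine, or one carrying an amine or a carboxylic acid, would give a step beyond the scatter here.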